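This account rests on a few compounds, and the source may have more. Where it says the series, first, only, none or still open, it means among the compounds named here.

Working notes on the series.

For the measured compounds named here, compound 1 `FC(F)(F)c1ccccc1Cn1nnc2c(NC3CCCCC3)nc(-c3ccccc3)nc21` gives, in an assay on isolated protein for binding affinity to adenosine receptor A1 (Bos taurus) (a higher number here means a weaker inhibitor, a lower number a stronger inhibitor), a value of 6800000 nM, the highest of the two numbers measured so far. Going by the values given here, its nearest neighbour is compound 2 `Fc1ccccc1Cn1nnc2c(NC3CCCCC3)nc(-c3ccccc3)nc21`, which in this assay gives 1150000 nM; the one step recorded, a 5.9-fold lower number from compound 1 to compound 2 (0.77 log units; beyond the scatter), is a change of fluoro in place of trifluoromethyl on an aromatic carbon, a modest step beyond the scatter.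

Compound 3 `CCCCNc1nc(-c2ccccc2)nc2c1nnn2Cc1ccccc1C(F)(F)F` has not been measured. It differs from compound 1 by butyl in place of cyclohexyl on a nitrogen on an aromatic ring, at the nitrogen on the aromatic ring of the shared core. Among the compounds with values here, the only recorded step, from compound 1 to compound 2, concerns a different part of the molecule, so no measured step bears directly on this exchange. With nothing to guide direction, no step beyond the scatter is assumed for the move from compound 1 to compound 3, and the uncertainty is set wide.

Compound 3 is therefore expected at 5000000 nM, within a range of 1200000 nM to 20000000 nM. The expected step from compound 1 is a 1.4-fold lower number from compound 1 to compound 3 (0.13 log units; within the scatter), estimated as within the scatter.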

Compound 3, inhibition constant: 6500000 nM
Compound 3: middle estimate off by 1.3-fold (0.11 log units), on the low side; measured number inside the range.
By their numbers in this assay, from the lowest: compound 2; then compounds 3 and 1 (each within the scatter of the next).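

In this assay, the step at the nitrogen on the aromatic ring, cyclohexylamino to butylamino, is a 1.0-fold lower number from compound 1 to compound 3 (0.02 log units; within the scatter) and lies within the scatter, so compounds 1 and 3 cannot be told apart in this assay. For the compounds shown here, this is the first reading at this position, and it shows that, with the rest of compound 1 kept, the six-membered non-aromatic ring of 6 heavy atoms can give way to an open butyl chain of 4 heavy atoms without a measurable difference, whereas the earlier step concerned only the fluoro and trifluoromethyl exchange elsewhere on the molecule. No measurement at hand accounts for this lack of difference.

The compounds shown leave open whether the same exchange would also leave the number unmoved with the fluoro group of compound 2 in place of trifluoromethyl, since only the pair of compounds 1 and 3 speaks to it. They also leave open how this nitrogen would respond to a longer chain, a phenyl ring, or a chain ending in an amine or a carboxylic acid.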